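Chloro for fluoro at the outer phenoxy ring

The source may hold more compounds than are shown below. What is called first, only, known or untested is meant among the compounds shown, and "the series" means these compounds.

Measured compounds:
- compound 1 `CC(Oc1ccc(Oc2ccc(Cl)cc2)cc1)C(=O)Cn1nnc(-c2ccccc2)n1` gives 6 in a physicochemical assay for lipophilicity, read by HPLC, tested at 5 mM; a lower number here means a more polar compound, a higher number a more lipophilic compound
- compound 2 `CC(Oc1ccc(Oc2ccc(F)cc2)cc1)C(=O)Cn1nnc(-c2ccc(Cl)cc2)n1` gives 6.2 in this assay

Compound 2 and compound 1 lie within the scatter of each other in this assay, so the two numbers show no difference that can be read. Among the measured compounds shown here, no pair of measured compounds differs in only one place, so no measured step is available for any single change.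

Compound 3 `CC(Oc1ccc(Oc2ccc(Cl)cc2)cc1)C(=O)Cn1nnc(-c2ccc(Cl)cc2)n1` is the next compound to be measured in this assay. It differs from compound 2 by chloro in place of fluoro on an aromatic carbon, para to a large group.

For this change a small upward step is expected, at the edge of the scatter, so that compound 3 is estimated at 6.5 with a range from 6.1 to 6.9. The expected step from compound 2 to compound 3 is a number 0.30 log units higher from compound 2 to compound 3 (within the scatter).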

Compound 3, partition coefficient: 6.8
Beside the measured number, compound 3's estimate is 0.30 log units below it; low and high end bracket the measured number.
By their numbers in this assay, from the lowest: compounds 1 and 2 (each within the scatter of the next); then compound 3.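

In this assay, among the compounds shown here, the change from 4-fluorophenoxy to 4-chlorophenoxy gives a number 0.60 log units higher from compound 2 to compound 3 (beyond the scatter) and is the first single change that can be read. Chloro in place of hydrogen on an aromatic carbon also gives a readable step, a number 0.80 log units higher from compound 1 to compound 3 (beyond the scatter) and so both changes that lead to compound 3 lie beyond the scatter and are modest in size. No measurement on hand accounts for either step.

From the compounds shown here alone, each change is seen only once, on one background, so it remains open whether either step would hold on another. Going by these compounds, it is also open how bromo, methoxy or an amine on the same aromatic carbon would compare with chloro and fluoro.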